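The source may report more compounds than this note shows. Statements on the series, on what has been measured and on what is new or still open speak of the compounds shown alone.

Measured in a functional assay on WM-115 cells (Homo sapiens) for cytotoxicity, read by MTT assay, with a stated time of 46 h; a lower number here means a stronger inhibitor, a higher number a weaker inhibitor:
- compound 1 `O=C1/C(=C\c2ccccc2)C(c2ccccc2)Oc2ccccc21`: 52600 nM
- compound 2 `O=C1/C(=C/c2ccccc2)C(c2ccccc2)Oc2ccccc21`: 59400 nM

Compound 2 cannot be told apart from compound 1 on these numbers. The move between them is a 1.1-fold higher number from compound 1 to compound 2 (0.05 log units; within the scatter), which lies within the scatter, and the one thing known about that pair is the fact that one of compounds 1 and 2 is drawn with a defined configuration and the other without, at the place where they differ.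

Compound 3 `O=C1/C(=C/c2ccccc2)C(c2ccccc2)Oc2ccc(O)cc21` keeps compound 2 and changes one place: hydroxy in place of hydrogen on an aromatic carbon. This puts a hydroxy in place of hydrogen on an aromatic carbon. Within the data shown here, the only measured step, a 1.1-fold higher number from compound 1 to compound 2 (0.05 log units; within the scatter), concerns a double bond and not this ring, so it bears on the new change only weakly. Among the measured compounds shown here, with no measured step showing what a hydroxy does here, no shift beyond the scatter in this assay is expected, and the direction stays open. The reference point remains compound 2 at 59400 nM. The expected change is a 1.3-fold lower number from compound 2 to compound 3 (0.12 log units; within the scatter). For compound 3 the estimated value is 45000 nM, with an expected range of 13000 nM to 110000 nM.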

Compound 3, half-maximal inhibitory concentration: 44500 nM
Compound 3: middle estimate off by 1.0-fold (0.00 log units), on the high side; the range from low to high includes it.
By their numbers in this assay, from the lowest: compounds 3, 1 and 2 (each within the scatter of the next).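

Among these compounds, this is the first measured change on an aromatic ring of the shared core, as the only earlier step concerned the double bond. In this assay the swap of hydrogen for hydroxy gives a 1.3-fold lower number from compound 2 to compound 3 (0.13 log units; within the scatter) and so leaves the number within the scatter, which means that adding this one group at this carbon, para to a fused ring, makes no readable difference to the cytotoxicity measured here. The data on hand give no explanation for what happens at this position.

Going by these compounds, whether a methoxy, an amine or a carboxylic acid on the same carbon would move the number beyond the scatter stays open. So does whether a hydroxy elsewhere on the core, or on the same carbon with the double bond drawn as in compound 1, would behave the same way.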